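Expected Solubility of Compound 4 from Three Measured Analogues

A few compounds are considered here, and "the series" means these few. Any claim that something is new, unique, unknown or untested is made for them only; others in the source may bear on it.

Of the compounds shown here, three sharing one core have been measured in a physicochemical assay for solubility, with a stated time of 18 h, at pH 7.4; on this read-out higher numbers stand for higher solubility and lower numbers for lower solubility. Compound 1 `COc1ccc(F)cc1CNCCCNc1ccnc2cc(Cc3ccc(F)cc3Cl)ccc12` gives 4200 nM in this assay; compound 2 `COc1ccc(F)cc1CNCCCNc1ccnc2cc(-c3ccc(F)cc3)ccc12` gives 32000 nM; compound 3 `CCC(CC)c1ccc2c(NCCCNCc3cc(F)ccc3OC)ccnc2c1` gives 4200 nM. Compound 3 thus stands level with compound 1, and together they hold the lowest numbers of the three, while compound 2 sits apart, as shown by a 7.6-fold lower number from compound 2 to compound 3 (0.88 log units; beyond the scatter).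

The unmeasured compound 4 `COc1ccc(F)cc1CNCCCNc1ccnc2cc(Oc3cccc(N(C)C)c3)ccc12` differs from compound 3 in one place: 3-(dimethylamino)phenoxy in place of pentan-3-yl on an aromatic carbon. For the measured compounds named here, two measured steps bear on this change, both at the same aromatic carbon. There is a 7.6-fold higher number from compound 1 to compound 2 (0.88 log units; beyond the scatter), and there is a 7.6-fold lower number from compound 2 to compound 3 (0.88 log units; beyond the scatter). Each is modest and beyond the scatter. The group entering compound 4 contains an aromatic ring, as does the group carried by compound 2, though it is joined through oxygen and brings two hydrogen-bond acceptors where pentan-3-yl brought none. On this basis compound 4 is expected to rise in this assay, by a 2.4-fold higher number from compound 3 to compound 4 (0.38 log units; beyond the scatter). That would place it between compound 3 and compound 2. The estimate for compound 4 is 10000 nM, with a range from 3000 nM to 40000 nM.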

Compound 4, solubility: 14500 nM
Compound 4: middle estimate off by 1.5-fold (0.16 log units), on the low side; the range from low to high includes it.
By their numbers in this assay, from the lowest: compounds 1 and 3 (each within the scatter of the next); then compound 4; then compound 2.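

At this aromatic carbon the earlier compounds had shown only two levels in this assay, with 4-fluorophenyl high and pentan-3-yl level with 2-chloro-4-fluorobenzyl. 3-(Dimethylamino)phenoxy adds a third level, showing a 3.5-fold higher number from compound 3 to compound 4 (0.54 log units; beyond the scatter) and a 3.5-fold higher number from compound 1 to compound 4 (0.54 log units; beyond the scatter), yet it stays short of 4-fluorophenyl, with a 2.2-fold lower number from compound 2 to compound 4 (0.34 log units; beyond the scatter). An aromatic ring in the group now goes with a higher number than pentan-3-yl in both compound 2 and compound 4, but compound 1 goes against any such pattern, as its 2-chloro-4-fluorobenzyl also holds an aromatic ring and its value is level with that of compound 3, so a ring alone does not set the number. No measurement given here accounts for these differences between the groups.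

The compounds shown leave open what the dimethylamino group and the oxygen link each contribute, as plain phenoxy and 4-fluorophenoxy do not appear among them. They also leave open where a carboxylic acid, an amide or a longer alkyl chain at this carbon would fall among these levels.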